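From a Ring on Nitrogen Back to an Amide Hydrogen

The source may report more compounds than this note shows. Statements on the series, on what has been measured and on what is new or still open speak of the compounds shown alone.

Of the compounds shown here, two sharing one core have been tested so far. Compound 1 `NC(=O)/C=C1/CCc2ccc(F)cc21` carries a primary amide, and in a functional assay on the whole organism with Mus musculus as the target, at a dose of 100 mg/kg by the intraperitoneal route (on this read-out higher numbers stand for more inhibition at the one dose given (going by the name of the read-out) and lower numbers for less inhibition), compound 1 gives 100%. Compound 2 `O=C(/C=C1\CCc2ccc(F)cc21)N1CCCC1`, in which the amide nitrogen belongs to a pyrrolidin-1-yl ring, gives 33% in this assay; this is the lowest of the two numbers, and compound 1 stands a long way above it, beyond the usual scatter. Compound 3 `O=C(/C=C1\CCc2ccc(F)cc21)NC1CC1` has not yet been measured. It differs from compound 2 in one place: cyclopropylamino in place of pyrrolidin-1-yl on a carbonyl carbon. Within the data shown here, no step between measured compounds has been recorded; the two values simply show compound 1, with its amide hydrogen, far above compound 2. For compound 3 the step from the pyrrolidine amide is expected to be upward and beyond the scatter, a number 37 percentage points higher from compound 2 to compound 3 (beyond the scatter). The expectation rests on compound 1, whose 100% shows what the same core reaches when the amide keeps a hydrogen. Compound 3 is estimated at 70%, within a range from 40% to 100%.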

Compound 3, a percentage reported as inhibition, in the whole organism at one dose (the size of the read-out at that dose, not a potency): 100%
Estimate against measurement, compound 3: 30 percentage points below; the range from low to high includes it.
By their numbers in this assay, from the lowest: compound 2; then compounds 1 and 3 (each within the scatter of the next).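

In this assay, putting cyclopropylamino in place of pyrrolidin-1-yl on a carbonyl carbon gives a number 67 percentage points higher from compound 2 to compound 3 (beyond the scatter), so this position responds strongly to the group on the amide nitrogen. A ring on that nitrogen is therefore compatible with a high read-out, as compound 3 keeps a small carbon ring and gives 100%. The change alters the ring and adds a hydrogen-bond donor at the same time, and no independent measurement explains the step.

The compounds shown cannot separate the ring size from the presence of the amide hydrogen. Ethylamino, which keeps that hydrogen without a ring, and azetidin-1-yl, which has a small ring without it, are the kinds of group that would pull these two changes apart.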